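The compounds below may be only part of what the source reports. "The series", "measured", "known", "first", "only" and "open" are said of these compounds alone.

Compound 1 `CC(C)/C=C/C(=O)Nc1cccc(Oc2nc(Nc3ccn(C)n3)nc3c2CSCC3)c1`: 33500 nM
Compound 2 `C=CC(=O)Nc1cccc(Oc2nc(Nc3cccc(OC)c3)nc3c2CSCC3)c1`: 10100 nM

In a functional assay on A549 cells (Homo sapiens) for antiproliferative activity, read by MTT assay, with a stated time of 72 h (a higher number here means a weaker inhibitor, a lower number a stronger inhibitor), compound 2 gives 10100 nM, the lower of the two numbers. Compound 1 gives 33500 nM, and the gap between them lies beyond the scatter of repeated measurements, so compound 2 is the stronger inhibitor of this pair.

The next compound to be tested is compound 3 `C=C(F)C(=O)Nc1cccc(Oc2nc(Nc3cccc(OC)c3)nc3c2CSCC3)c1`, which is built from compound 2 by a single small edit: fluoro in place of hydrogen on a double-bonded chain carbon bound to a carbonyl carbon. In words, this puts fluoro in place of hydrogen on a double-bonded chain carbon bound to a carbonyl carbon. The rest of the molecule stays the same.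

Among the compounds with values here, no measured pair here differs in only one place, so the data offer no direct guide to the size of such a step. Within the data shown here, the only anchor is compound 2 at 10100 nM. No step beyond the scatter is therefore expected in this assay, in either direction, and the estimate carries a wide margin. The estimated change is a 1.0-fold lower number from compound 2 to compound 3 (0.00 log units; within the scatter). For compound 3 the expected value is 10000 nM, with an estimated range from 4000 nM to 25000 nM.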

Compound 3, half-maximal inhibitory concentration: 29600 nM
The estimate for compound 3 lay 3.0-fold (0.47 log units) below the measured number; measured number above the stated range.
By their numbers in this assay, from the lowest: compound 2; then compounds 3 and 1 (each within the scatter of the next).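

In this assay, putting fluoro in place of hydrogen on the double-bonded chain carbon bound to a carbonyl carbon gives a 2.9-fold higher number from compound 2 to compound 3 (0.47 log units; beyond the scatter) and so weakens the inhibitor by a modest step. Within the data shown here, this is the first direct reading of a single change, as compound 1 and compound 2 differ in more than one place and could not show what one position contributes on its own. It shows that this position is not silent, since one added heavy atom on the vinylcarbonyl group is enough to move the number beyond the scatter, but nothing available here explains the loss.

A chloro or a methyl group on the same carbon would help to show whether the step is particular to fluoro or comes with any replacement of that hydrogen. A single pair also leaves open whether the same edit would move the number as far with a different group in place of the 3-methoxyphenyl amine of compound 2 and compound 3, such as a 3-chlorophenyl amine.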